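The source may hold more compounds than are shown below. What is called first, only, known or untested is meant among the compounds shown, and "the series" means these compounds.

Measured so far in a functional assay on A2780 cells (Homo sapiens) for antiproliferative activity, read by MTT assay, with a stated time of 48 h; on this read-out higher numbers stand for weaker inhibition and lower numbers for stronger inhibition:
compound 1 `COc1ccc(C(=O)c2ccc(OC)c3c2C=CC(C)(C)O3)c(NC(=O)CN(C)C)c1` gives 3990 nM
compound 2 `C=C(c1cc(OC)c(OC)c(OC)c1)c1ccc(OC)cc1NC(=O)CN` gives 30 nM
compound 3 `C=C(c1ccc2c(c1)C=CC(C)(C)O2)c1ccc(OC)cc1NC(=O)CNCC` gives 1870 nM

Compound 2 holds the lowest of these three numbers, and both of the others lie well beyond the usual scatter from it. The next compound to be tested is compound 4 `C=C(c1cc(OC)c(OC)c(OC)c1)c1ccc(OC)cc1NC(=O)CNCC`, which keeps the core of compound 2 and alters only its side chain. The structural change is ethyl in place of hydrogen on an amine nitrogen and amounts to ethyl in place of hydrogen on an amine nitrogen, so that aminomethyl becomes (ethylamino)methyl.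

Among the measured compounds shown here, no measured pair shows this change on its own. Compound 3 also carries the ethylamino group and gives 1870 nM in this assay but differs from compound 2 in the rest of its structure as well, so its high number cannot be read as the effect of the ethyl group alone. It does leave open some loss of activity, and the estimate leans modestly that way. The expected change is a 3.0-fold higher number from compound 2 to compound 4 (0.48 log units; beyond the scatter) in the direction of weaker inhibition, with a result inside the scatter still possible. Compound 4 is expected at 90 nM (estimated range 20 nM to 400 nM).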

Compound 4, half-maximal inhibitory concentration: 450 nM
Compound 4: the middle estimate sits 5.0-fold (0.70 log units) below what was measured; the whole stated range lies below it.
By their numbers in this assay, from the lowest: compound 2; then compound 4; then compound 3; then compound 1.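

In this assay, ethyl in place of hydrogen on an amine nitrogen, with nothing else in the structure altered, gives a 15-fold higher number from compound 2 to compound 4 (1.18 log units; beyond the scatter), a large step towards weaker inhibition. The earlier compounds shown here could not isolate this change, as compound 3 carries the same ethylamino group but also differs in the rest of its structure; this single-place comparison shows that, on this core, activity depends strongly on what sits on the amine nitrogen, with aminomethyl giving much stronger inhibition than (ethylamino)methyl. Nothing given here accounts for the size of this step.

The compounds shown leave open how a methyl group, a longer chain such as propyl, or a second substituent on the same nitrogen, as in a dimethylamino group, would compare with hydrogen and ethyl on this core. They also leave open whether a free amino group in place of the ethylamino group on the core of compound 3 would bring a step of similar size.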